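One Stereocentre Redrawn, Stability Still Open

The source may report more compounds than this note shows. Statements on the series, on what has been measured and on what is new or still open speak of the compounds shown alone.

In an ADME assay on microsomes from liver (Homo sapiens) for metabolic stability, using NADPH, with a stated time of 10 min (on this read-out lower numbers stand for a less stable compound and higher numbers for a more stable compound), compound 1 (`NCCCCN(C[C@@H]1Cc2cccnc2CN1)[C@H]1CCCc2cccnc21`) gives 92% and compound 2 (`NCCCCN(C[C@H]1Cc2nccnc2CN1)[C@H]1CCCc2cccnc21`) gives 84% and so stands within the usual scatter of compound 1. Compound 3 (`NCCCCN(C[C@@H]1Cc2nccnc2CN1)[C@H]1CCCc2cccnc21`) is still unmeasured. Its change from compound 2 (the two compounds have the same atoms and bonds and differ only in configuration as drawn: 1 of 2 stereo elements differ; a stereocentre at a saturated ring carbon is drawn R in compound 2 and S in compound 3) is that a stereocentre at a saturated ring carbon is drawn R in compound 2 and S in compound 3. Among the measured compounds shown here, no measured pair shows such a change alone, so the expected a number 1 percentage points higher from compound 2 to compound 3 (within the scatter) stays within the scatter in this assay with no direction favoured. Compound 3 is estimated at 85% with an expected range from 68% to 96% for now.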

Compound 3, percent of the compound remaining: 87%
Estimate against measurement, compound 3: 2 percentage points below, and the stated range covers the measured number.
By their numbers in this assay, from the lowest: compounds 2, 3 and 1 (each within the scatter of the next).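

In this assay, redrawing the saturated ring carbon from R to S gives a number 3 percentage points higher from compound 2 to compound 3 (within the scatter). Among the compounds shown here, this is the only measured pair in which the stereocentre changes alone, so it isolates that single change: the fact that compounds 2 and 3 differ only in the configuration as drawn. At this position, then, the configuration as drawn makes no difference that can be told from the scatter in this assay.

The compounds shown leave open whether the other stereocentre behaves the same way. They also leave open what a carboxylic acid or a longer chain on the shared core would do to this read-out.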